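An Amino Group Added to the Core of Compound 1

The compounds below may be only part of what the source reports. "The series", "measured", "known", "first", "only" and "open" are said of these compounds alone.

Compound 1 `CC(C)OC(=O)N1CCC(Oc2ncnc3c2CCN3c2ccc(S(C)(=O)=O)cc2F)CC1` gives 50.1 nM in a functional assay on CHO-K1 cells for agonist activity at Glucose-dependent insulinotropic receptor (Homo sapiens), read by a luciferase reporter, with a stated time of 5 h (a higher number here means that more compound is needed for the effect, a lower number that less compound is needed), the second highest of the three numbers measured. Compound 2 `CS(=O)(=O)c1ccc(N2CCc3c(OC4CCN(C(=S)Sc5ccccc5)CC4)ncnc32)c(F)c1` gives 12.6 nM, and compound 3 `CC(C)S(=O)(=O)N1CCC(Oc2ncnc3c2CCN3c2ccc(S(C)(=O)=O)cc2F)CC1` gives 1260 nM. Compound 4 `CC(C)OC(=O)N1CCC(Oc2nc(N)nc3c2CCN3c2ccc(S(C)(=O)=O)cc2F)CC1` is not yet measured; it differs from compound 1 by amino in place of hydrogen on an aromatic carbon. The measured steps all alter a different site, the group on the amine nitrogen in a ring: a 4.0-fold lower number from compound 1 to compound 2 (0.60 log units; beyond the scatter) and a 25-fold higher number from compound 1 to compound 3 (1.40 log units; beyond the scatter). They therefore say nothing direct about a change on the aromatic carbon. Among the measured compounds shown here, no measured step bears on this change, so the number for compound 4 is expected to stay close to that of compound 1, a step of a 1.0-fold lower number from compound 1 to compound 4 (0.00 log units; within the scatter), with no movement beyond the scatter. The estimate for compound 4 is 50 nM, with a range from 12 nM to 250 nM.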

Compound 4, half-maximal effective concentration: 794 nM
Compound 4: middle estimate off by 16-fold (1.20 log units), on the low side, outside the stated range (above it).
By their numbers in this assay, from the lowest: compound 2; then compound 1; then compounds 4 and 3 (each within the scatter of the next).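

The hydrogen on this aromatic carbon, between two ring nitrogen atoms, cannot be exchanged freely: in this assay, amino in its place gives a 16-fold higher number from compound 1 to compound 4 (1.20 log units; beyond the scatter), a large step. The earlier steps shown here showed a response only to changes on the amine nitrogen in a ring, whereas this one shows that the core of compound 1 responds as well. Nothing available gives a cause for this step.

From the compounds shown here alone, whether methyl or methylamino on this carbon would raise the number as amino does remains open. So does whether amino would give a step of similar size alongside a different group on the amine nitrogen.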